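The source may report more compounds than this note shows. Statements on the series, on what has been measured and on what is new or still open speak of the compounds shown alone.

Of the compounds shown here, two sharing one core have been tested in a functional assay on U-87MG ATCC cells (Homo sapiens) for inhibition, read by MTT assay, with a stated time of 72 h; on this read-out lower numbers stand for stronger inhibition and higher numbers for weaker inhibition. Compound 1 `COc1cc2c(Oc3ccc(NC(=O)c4nn(-c5ccccc5C)c(=O)cc4C)cc3F)ccnc2cc1OCCCN1CCCCC1` gives 2500 nM in this assay, and compound 2 `COc1cc2c(Oc3ccc(NC(=O)c4nn(-c5ccccc5C)c(=O)cc4C)cc3F)ccnc2cc1OCCCN1CCC(C)CC1` gives 2240 nM. The step from one to the other, a methyl in place of hydrogen on a saturated ring carbon, reads a 1.1-fold lower number from compound 1 to compound 2 (0.05 log units; within the scatter). Among the compounds with values here, compound 2 therefore holds the lowest of the two numbers, yet its only neighbour, compound 1, sits within the scatter, so no order between the two can be claimed.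

Compound 3 `COc1cc2c(Oc3ccc(NC(=O)c4nn(-c5ccccc5C)c(=O)cc4C)cc3F)ccnc2cc1OCCCN1CCN(C)CC1` has not yet been measured. It differs from compound 2 in one place: 4-methylpiperazin-1-yl in place of 4-methylpiperidin-1-yl on a saturated chain carbon, three bonds along the chain from an oxygen on an aromatic ring. Within the data shown here, the single measured step does not touch this change; it moved only a methyl on the ring and stayed within the scatter. Among the measured compounds shown here, no measured step shows what exchanging 4-methylpiperidin-1-yl for 4-methylpiperazin-1-yl on that chain carbon does in this assay. The expectation is therefore a step of a 1.0-fold lower number from compound 2 to compound 3 (0.01 log units; within the scatter), not clearly beyond the scatter in either direction. Compound 3 is estimated at 2200 nM, with a range from 900 nM to 5500 nM.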

Compound 3, half-maximal inhibitory concentration: 3720 nM
The estimate for compound 3 lay 1.7-fold (0.23 log units) below the measured number; measured number inside the range.
By their numbers in this assay, from the lowest: compounds 2, 1 and 3 (each within the scatter of the next).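

In this assay, 4-methylpiperazin-1-yl in place of 4-methylpiperidin-1-yl on a saturated chain carbon, three bonds along the chain from an oxygen on an aromatic ring, reads a 1.7-fold higher number from compound 2 to compound 3 (0.22 log units; within the scatter), and 4-methylpiperazin-1-yl in place of piperidin-1-yl at that same place reads a 1.5-fold higher number from compound 1 to compound 3 (0.17 log units; within the scatter). Compound 3 thus adds what the first pair could not show: a second hetero atom in the six-membered ring, not only a methyl on a ring carbon, still gives a number that cannot be told apart from those of compound 1 and compound 2, so the three compounds cannot be ranked at this place. Nothing available here bears on why these numbers sit as they do.

Still open, as far as these compounds go, is whether a different end group on the chain, such as morpholin-4-yl, an open-chain dimethylamino group or a carboxylic acid, would step clearly beyond the scatter. Also open, from the compounds shown here alone, is whether a shorter ethyl chain or a longer butyl chain carrying these same rings would read any differently on the shared core.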